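The source may hold more compounds than are shown below. What is called first, only, known or untested is meant among the compounds shown, and "the series" means these compounds.

Compound 2 `COCCCn1c(N2CCN(C)CC2)nc2ccccc21` stands as the higher of the two numbers recorded in a functional assay on ileum for inhibition of histamine H1 receptor (Cavia porcellus) (on this read-out higher numbers stand for weaker inhibition and lower numbers for stronger inhibition), where compound 2 gives 860 nM. Its nearest neighbour is compound 1 `C#CCOCCn1c(N2CCN(C)CC2)nc2ccccc21`, which in this assay gives 12 nM; the step between them is a 72-fold higher number from compound 1 to compound 2 (1.86 log units; beyond the scatter). The change now followed leads to compound 3 `COCCn1c(N2CCN(C)CC2)nc2ccccc21`, with methoxy in place of methoxymethyl on a saturated chain carbon, two bonds along the chain from an aromatic nitrogen. Among the compounds with values here, no measured step describes this shortening of the chain, and the single step known, from compound 1 to compound 2, changes the chain's end group as much as its length, so it bears on this step only loosely. Compound 3 shares the shorter chain of compound 1 but keeps the methoxy end of compound 2, so a number between the two measured values is expected, with a 2.9-fold lower number from compound 2 to compound 3 (0.46 log units; beyond the scatter). For compound 3 the estimate in this assay is 300 nM, within a range from 60 nM to 1500 nM.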

Compound 3, half-maximal inhibitory concentration: 13 nM
For compound 3 the middle estimate is 23-fold (1.36 log units) above the measured one, outside the stated range (below it).
By their numbers in this assay, from the lowest: compounds 1 and 3 (each within the scatter of the next); then compound 2.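

Going from 3-methoxypropyl to 2-methoxyethyl with the methoxy end kept gives a 66-fold lower number from compound 2 to compound 3 (1.82 log units; beyond the scatter) in this assay, so at this place on a saturated chain carbon the length of the chain alone moves the number by a large step. Hydrogen in place of ethynyl on a saturated chain carbon bound to an oxygen on a saturated carbon gives a 1.1-fold higher number from compound 1 to compound 3 (0.03 log units; within the scatter) and so leaves the number within the scatter. Among these compounds, the large step seen earlier as a 72-fold higher number from compound 1 to compound 2 (1.86 log units; beyond the scatter) is therefore matched by the change in chain length, while the ethynyl shows no effect beyond the scatter on this chain.

The compounds shown leave open what a longer chain than 3-methoxypropyl, or a 2-substituted ethyl chain ending in an amine or a carboxylic acid instead of methoxy, would give. Nothing at hand explains why the number moves so sharply with this change.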